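The source may hold more compounds than are shown below. What is called first, only, known or untested is meant among the compounds shown, and "the series" means these compounds.

Of the compounds shown here, two have been measured in a functional assay (spleen, spleen) for activation, with Mus musculus as the target; a lower number here means that less compound is needed, a higher number that more compound is needed for the effect. Compound 1, `Cc1ccc(Cn2c(O)nc3c(N)ncnc32)cc1`, gives 10 uM in this assay. Compound 2, `CCCCCNc1nc(N)c2nc(O)n(Cc3ccccc3)c2n1`, gives 0.1 uM in this assay. Of these two numbers, compound 2 holds the lower one, and the gap to compound 1 lies well beyond the usual scatter of repeated measurements.

Compound 3, `CCc1nc(N)c2nc(O)n(Cc3ccccc3)c2n1`, has not yet been measured. It differs from compound 2 in one place: ethyl in place of pentylamino on an aromatic carbon. Going by the values given here, no pair of measured compounds shows a change of this kind, so there is no direct guide to its size. The step from compound 2 to compound 3 is expected to be a 10-fold higher number from compound 2 to compound 3 (1.00 log units; beyond the scatter), toward a larger amount of compound needed, and beyond the scatter. Compound 3 is therefore expected to give about 1 uM in this assay, most likely between 0.2 uM and 10 uM.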

Compound 3, minimum effective concentration: 1 uM
Beside the measured number, compound 3's estimate shows no gap at the digits printed; measured number inside the range.
By their numbers in this assay, from the lowest: compound 2; then compound 3; then compound 1.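

Putting ethyl in place of pentylamino on the aromatic carbon between two ring nitrogen atoms gives a 10-fold higher number from compound 2 to compound 3 (1.00 log units; beyond the scatter) in this assay. Going by these compounds alone, this is the first sign that the group at this position affects how much compound is needed, though this single pair cannot show whether the chain length or the nitrogen attached to the ring matters, as both change together. Nothing measured here gives a reason for the size of this step.

As far as these compounds go, an ethylamino group would keep that nitrogen with a short chain, while a plain pentyl chain would keep the five carbons without it, and where either would fall relative to compound 2 and compound 3 remains open. From the compounds shown here alone, it is also open how a carboxylic acid or a longer amine at this position would behave.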